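Swapping the Acid Tail for a Tetrazole on the Shared Core

The compounds below may be only part of what the source reports. "The series", "measured", "known", "first", "only" and "open" are said of these compounds alone.

Of the compounds shown here, two have so far been tested in a functional assay (lung) for inhibition, with Cavia porcellus as the target; a lower number here means a stronger inhibitor, a higher number a weaker inhibitor. Compound 1 `CC(CCCC(=O)O)c1cccc(OCc2ccc3ccccc3n2)c1` gives 500 nM, while compound 2 `CC(CCC(=O)O)Cc1ccc(OCc2ccc3ccccc3n2)cc1` gives 100 nM. Of these two numbers, compound 1 stands at the higher one, so it is the weaker inhibitor of the pair, and the gap between compound 1 and compound 2 is wider than the usual scatter of repeated measurements. The two compounds differ in more than one place, so no single structural step can be read from them.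

Compound 3 `c1cc(CCCCc2nnn[nH]2)cc(OCc2ccc3ccccc3n2)c1` has not yet been measured. Compared with compound 1 it carries 4-(1H-tetrazol-5-yl)butyl in place of 4-carboxy-1-methylbutyl on an aromatic carbon. Among the compounds with values here, no pair of measured compounds shows a change of this kind, so there is no measured step to lean on. The acidic group is kept in a different form and the chain loses its branch, and the expectation is a modest move, the step from compound 1 to compound 3 in this assay being estimated as a 1.7-fold lower number from compound 1 to compound 3 (0.22 log units; within the scatter), close to the edge of the scatter. For compound 3 the estimated value in this assay is 300 nM, with a likely range from 80 nM to 1500 nM.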

Compound 3, half-maximal inhibitory concentration: 105 nM
For compound 3 the middle estimate is 2.9-fold (0.46 log units) above the measured one, within the range that was stated.
By their numbers in this assay, from the lowest: compounds 2 and 3 (each within the scatter of the next); then compound 1.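

In this assay, within the data shown here, putting 4-(1H-tetrazol-5-yl)butyl in place of 4-carboxy-1-methylbutyl on this aromatic carbon gives a 4.8-fold lower number from compound 1 to compound 3 (0.68 log units; beyond the scatter) as the first step that can be tied to a single place on the shared core. It shows that this position accepts a group ending in a five-membered aromatic ring with 4 hetero atoms instead of a carboxylic acid, and that inhibition grows stronger rather than being lost with this swap. Nothing measured here explains the gain, and it cannot be assigned to any one part of the swap.

The swap changes the end group and removes the methyl branch in one move, so the compounds shown cannot separate the two: a plain 4-carboxybutyl chain, or a tetrazole chain that keeps the methyl branch, would tell them apart. Also open, as far as these compounds go, is how a shorter or longer chain carrying the tetrazole, or a sulfonamide or amide at the same end, would compare on this core.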